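Cytotoxicity notes on a thiophene-bearing amide series

This account rests on a few compounds, and the source may have more. Where it says the series, first, only, none or still open, it means among the compounds named here.

The series shares a core carrying an isopropyl group and a thiophene, with an amide linking the core to a second aromatic ring. Compound 1 `CC(C)n1ccc2c(C(=O)Nc3ccccn3)cc(-c3cccs3)nc21` was tested in an ADME assay on LLC-MK2 cells (Macaca mulatta) for cytotoxicity, read by spectrophotometry and crystal violet staining, with a stated time of 4 days; on this read-out lower numbers stand for higher toxicity in this test and higher numbers for lower toxicity in this test; for compound 1 the result is a limit of the assay, > 200000 nM. Compound 2 `CC(C)n1ncc2c(NC(=O)c3ccc(F)cc3)cc(-c3cccs3)nc21` differs in the core and in the direction of the amide; in this assay compound 2 gives 50000 nM. Compound 3 `CC(C)n1ncc2c(C(=O)Nc3ccc(F)cc3F)cc(-c3cccs3)nc21` carries a 2,4-difluorophenyl on the amide nitrogen; in this assay compound 3 also sits at a limit of the assay, > 200000 nM. Compound 3 thus stands at the limit of > 200000 nM in this assay, at which 2 of the 3 values shown sit, where no number was reached. Among the compounds with values here, no single-change pair among the measured compounds is available, so no measured step can be stated.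

Compound 4 `CC(C)n1ncc2c(C(=O)Nc3cccc(S(N)(=O)=O)c3)cc(-c3cccs3)nc21` is the next member: 3-sulfamoylphenyl in place of 2,4-difluorophenyl on an amide-type nitrogen. Compound 4 keeps the core, the isopropyl, the thiophene and the amide of compound 3. Given that compound 3 gives > 200000 nM in this assay, the step to compound 4 is expected to be none beyond the scatter, so that compound 4 is estimated to stay near the limit, most likely again reported as a limit. The step from compound 3 to compound 4 is therefore expected to be a number no higher from compound 3 to compound 4 (the limit leaves the size open). Compound 4 is estimated at 200000 nM in this assay, within a range from 60000 nM to 400000 nM.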

Compound 4, half-maximal cytotoxic concentration: 25000 nM
The estimate for compound 4 lay 8.0-fold (0.90 log units) above the measured number; measured number below the stated range.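

Within the data shown here, with the core, the isopropyl, the thiophene and the amide held fixed, this assay records an at least 8.0-fold lower number from compound 3 to compound 4 (0.90 log units; beyond the scatter), the first single-change step. On this read-out a lower number stands for higher toxicity, so exchanging the group on the amide-type nitrogen is enough on its own to give a measured number in place of a limit, and this position cannot be treated as neutral for cytotoxicity. The value of compound 3 is a limit, so the step fixes only a minimum size and leaves its full extent unknown: the limit of > 200000 nM in this assay, at which 2 of the 4 values shown sit.

This single pair cannot separate the gain of the sulfamoyl group from the loss of the two fluorines, since both happen in the same exchange, and it gives no cause for the step. Also open, going by these compounds, is how this assay would read with an unsubstituted phenyl on the amide nitrogen, or with an amine or a carboxylic acid in place of the sulfamoyl group, which would show whether the sulfonamide itself matters.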